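The source may report more compounds than this note shows. Statements on the series, on what has been measured and on what is new or still open speak of the compounds shown alone.

Working notes on the series. The shared core is seen in compound 1 `CCC1(CCCCN2CCN(c3ccc(Cl)cc3)CC2)C(=O)Nc2ccccc21`. In a functional assay on the whole organism (strain Wistar) with Rattus norvegicus as the target, with a stated time of 5 min (a higher number here means that more compound is needed for the effect, a lower number that less compound is needed), compound 1 gives 10 mg/kg. Within the data shown here, compound 2 `CCC1(CCCCN2CCN(c3cccc(Cl)c3)CC2)C(=O)Nc2c(Cl)cc(Cl)cc21` differs from compound 1 at more than one place, so no single step connects the two. In this assay compound 2 reaches only a limit, > 20 mg/kg, not a number. Among the measured compounds shown here, compound 1 therefore stands as the only numbered value in this assay; the other entry is the limit of > 20 mg/kg in this assay, at which 1 of the 2 values shown sits. Compound 3 `CCC1(CCCCN2CCN(c3ccc(OC)cc3)CC2)C(=O)Nc2ccccc21`, not yet measured, differs from compound 1 by methoxy in place of chloro on an aromatic carbon. For the measured compounds named here, no measured pair carries this same change, so the data give no direction for it; the expectation is a step from compound 1 to compound 3 of no more than modest size, if any, toward more compound needed. Compound 3 is expected at 15 mg/kg, within a range from 7 mg/kg to 30 mg/kg. The step this implies from compound 1 is the expected 1.5-fold higher number from compound 1 to compound 3 (0.18 log units; within the scatter).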

Compound 3, minimum effective dose: > 20 mg/kg
Compound 3: only a limit was reported; the forecaster's own chance of this, stated with the estimate: 25%; middle value at least 1.3-fold (0.12 log units) from the limit.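

Among these compounds, this is the first single-place change the series offers: on a six-membered aromatic ring of carbon only, para to a large group, 4-chlorophenyl becomes 4-methoxyphenyl, and in this assay this gives an at least 2.0-fold higher number from compound 1 to compound 3 (0.30 log units; that floor lies within the scatter). That step is only a floor, so the data show that methoxy at this position does not lower the number but not how far it raises it. Compound 1 remains the only compound with a numbered value, and the rest of the series sits at the limit: the limit of > 20 mg/kg in this assay, at which 2 of the 3 values shown sit.

Going by these compounds, it remains open whether fluoro, methyl or an amine at this position would give a numbered value, and how far the chloro of compound 1 can be replaced at all. On these data alone, the effect of a longer chain on the shared core also remains unknown.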